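The compounds below may be only part of what the source reports. "The series", "measured", "known", "first", "only" and "open" are said of these compounds alone.

Three compounds set the scene. Compound 1 `O=S(=O)(Nc1ccc(-c2nc3cc(NS(=O)(=O)c4ccccc4)ccc3o2)cc1)c1ccccc1` gives 80000 nM in an assay on cells for inhibition of HSP60/HSP10 (Homo sapiens), with a stated time of 60 min (a higher number here means a weaker inhibitor, a lower number a stronger inhibitor), and compound 3 `O=S(=O)(Nc1ccc(-c2nc3ccccc3o2)cc1)c1cccc(Cl)c1` gives 54000 nM. Among the measured compounds shown here, compound 2 `Cc1ccc(S(=O)(=O)Nc2ccc3oc(-c4ccccc4)nc3c2)cc1` is reported only as a limit of the assay, > 100000 nM, the one value among the three that sits at the limit of > 100000 nM in this assay, at which 1 of the 3 values shown sits. Compound 2 therefore stands at the weak end of what this set shows, with no number of its own to place it. Compound 4 `O=S(=O)(Nc1ccc2oc(-c3ccccc3)nc2c1)c1ccccc1Cl` differs from compound 2 by 2-chlorophenyl in place of 4-methylphenyl on a sulfonyl sulfur. For the measured compounds named here, no measured pair spans this change. The two numbered compounds, compound 1 and compound 3, both lie within the scatter of each other, so compound 4 is expected to remain weak, with a step from the limit that is estimated at an at least 1.2-fold lower number from compound 2 to compound 4 (0.09 log units; that floor lies within the scatter). Compound 4 is estimated at 80000 nM, between 30000 nM and 300000 nM.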

Compound 4, half-maximal inhibitory concentration: > 100000 nM
Compound 4 ended at the assay's limit; the forecaster's own chance of this, stated with the estimate: 45%; middle value at least 1.2-fold (0.09 log units) from the limit.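

Compound 2 and compound 4 both stand at a limit of this assay, so no step can be read for 2-chlorophenyl in place of 4-methylphenyl: the limit of > 100000 nM in this assay, at which 2 of the 4 values shown sit. The compounds shown leave open how these two actually compare.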